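Benzamide with bare phenyl replacing the aryl urea of compound 3

The compounds below may be only part of what the source reports. "The series", "measured", "known", "first", "only" and "open" are said of these compounds alone.

Measured so far:
compound 1 `COc1cc(-c2nn(-c3cccc(NC(=O)Nc4ccc(Cl)c(Cl)c4)c3)cc2-c2ccncc2)ccc1Cl`, > 50000 nM (a limit)
compound 2 `COc1cc(-c2nn(-c3cccc(NC(=O)c4ccc(Cl)c(C(F)(F)F)c4)c3)cc2-c2ccncc2)ccc1Cl`, > 32500 nM (a limit)
compound 3 `COc1cc(-c2nn(-c3cccc(NC(=O)Nc4ccc(Cl)c(C(F)(F)F)c4)c3)cc2-c2ccncc2)ccc1Cl`, > 32500 nM (a limit)

In a functional assay on MCF7 cells (Homo sapiens) for inhibition, read by sulforhodamine B assay, with a stated time of 48 h (a lower number here means a stronger inhibitor of growth, a higher number a weaker inhibitor of growth), compound 3 sits at a limit, > 32500 nM. Compound 2 likewise sits at a limit, > 32500 nM. Compound 1 sits at a limit, > 50000 nM. Two of the three values therefore share one limit of > 32500 nM in this assay, at which 2 of the 3 values shown sit, and the third a higher one (the limit of > 50000 nM in this assay, at which 1 of the 3 values shown sits). No step among these three can be read: a step that the two limits leave unreadable from compound 1 to compound 2; a step that the two limits leave unreadable from compound 1 to compound 3; a step that the two limits leave unreadable from compound 2 to compound 3.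

Compound 4 `COc1cc(-c2nn(-c3cccc(NC(=O)c4ccccc4)c3)cc2-c2ccncc2)ccc1Cl` differs from compound 3 by phenyl in place of (4-chloro-3-(trifluoromethyl)phenyl)amino on a carbonyl carbon. The nearest measured comparison, the change from urea to amide between compound 2 and compound 3, is itself unreadable, so no direction of any size can be drawn from the shown steps. All measured values sit at limits, and nothing in them suggests that compound 4 leaves that region. It is expected that compound 4 gives 40000 nM in this assay, with a range from 10000 nM to 100000 nM, most likely again reported as a limit. The step this estimate implies is a step that the limit leaves unreadable from compound 3 to compound 4.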

Compound 4, concentration for total growth inhibition: > 100000 nM
Compound 4 gave a limit, no number; the forecaster's own chance of this, stated with the estimate: 70%; at least 2.5-fold (0.39 log units) between middle value and limit.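

In this assay, among these compounds, compound 4 gives only a limit, > 100000 nM; compound 1, compound 2 and compound 3 are also limits, so no step to compound 4 can be read. The compounds shown leave open whether urea, amide or ring substitution affects growth inhibition at all.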